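Aryl change on the ring nitrogen of compound 1

The source may hold more compounds than are shown below. What is called first, only, known or untested is meant among the compounds shown, and "the series" means these compounds.

For the measured compounds named here, compound 1 `COc1ccc(N2C(=O)N(Cc3c(F)cc(F)cc3F)c3ccccc3S2(=O)=O)cc1OC` gives 2 nM in an assay on HEK293 cells for displacement of a labelled ligand from Orexin receptor type 2 (Homo sapiens), read by scintillation counting, with a stated time of 90 min (a higher number here means a weaker inhibitor, a lower number a stronger inhibitor), the lowest of the two numbers so far. Compound 2 `COc1ccc(N2C(=O)N(Cc3ccccc3F)c3ccccc3S2(=O)=O)cc1OC` gives 6.31 nM in this assay; the step of a 3.2-fold higher number from compound 1 to compound 2 (0.50 log units; beyond the scatter) concerns only the benzyl group. Compound 3 `COc1cc(N2C(=O)N(Cc3c(F)cc(F)cc3F)c3ccccc3S2(=O)=O)ccn1` is not yet measured; it differs from compound 1 by 2-methoxypyridin-4-yl in place of 3,4-dimethoxyphenyl on an amide-type nitrogen in a ring. Going by the values given here, no measured step bears on this position, so the direction is open and the expectation stays near compound 1 with a wide range, leaning to a weaker number. The estimate for compound 3 is 6 nM, with a range of 1.5 nM to 25 nM. For compound 3 the expected step is a 3.0-fold higher number from compound 1 to compound 3 (0.48 log units; beyond the scatter).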

Compound 3, inhibition constant: 63.1 nM
Compound 3: the middle estimate sits 11-fold (1.02 log units) below what was measured; the whole stated range lies below it.
By their numbers in this assay, from the lowest: compound 1; then compound 2; then compound 3.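

This position is sensitive in this assay: with the 2,4,6-trifluorobenzyl group unchanged, 2-methoxypyridin-4-yl in place of 3,4-dimethoxyphenyl gives a 32-fold higher number from compound 1 to compound 3 (1.50 log units; beyond the scatter) and so moves the number further than the benzyl change, which gives a 3.2-fold higher number from compound 1 to compound 2 (0.50 log units; beyond the scatter) in the earlier step. The exchange alters the ring atoms and the methoxy count together, so the two contributions cannot be separated. No measurement here accounts for the size of this step.

Open, as far as these compounds go, is which of those two alterations carries the step. A plain phenyl group, or an amine in place of the methoxy group on the 2-methoxypyridin-4-yl ring, would bear on that question.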